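The compounds below may be only part of what the source reports. "The series", "measured", "known", "first", "only" and "open" are said of these compounds alone.

Compound 1 `NC[C@H]1O[C@H](CO)[C@@H](O)[C@H](O)[C@H]1O` gives 31600000 nM; compound 2 `NC[C@@H]1O[C@H](CO)[C@@H](O)[C@H](O)[C@H]1O` gives 15800000 nM; compound 3 `OC[C@H]1O[C@H](F)[C@H](F)[C@@H](O)[C@@H]1O` gives 200000 nM.

In an assay on isolated protein (Sus scrofa) for inhibition of glycogen phosphorylase, brain form (Homo sapiens) (on this read-out higher numbers stand for weaker inhibition and lower numbers for stronger inhibition), compound 1 gives the highest of the three numbers. Compound 2 differs from it only in configuration, and the step of a 2.0-fold lower number from compound 1 to compound 2 (0.30 log units; within the scatter) lies within the scatter, as the fact that they differ only in the configuration as drawn the fact that compounds 1 and 2 differ only in the configuration as drawn shows. Compound 3 gives a number that sits well beyond the scatter from compound 1.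

Compound 4 `CNNC(=O)[C@H]1O[C@H](CO)[C@@H](O)[C@H](O)[C@H]1O` carries (methylamino)carbamoyl in place of aminomethyl on a saturated ring carbon. Within the data shown here, no measured step changes a group at this carbon, so the measured steps say nothing about this change. Compound 4 is therefore expected to stay in the weak range of compound 1, with a step estimated at a 7.9-fold lower number from compound 1 to compound 4 (0.90 log units; beyond the scatter). The estimate for compound 4 is 4000000 nM, with a range from 600000 nM to 25000000 nM.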

Compound 4, inhibition constant: 2000000 nM
Compound 4: the middle estimate sits 2.0-fold (0.30 log units) above what was measured; measured number inside the range.
By their numbers in this assay, from the lowest: compound 3; then compound 4; then compounds 2 and 1 (each within the scatter of the next).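

Among these compounds, compound 4 is the first case in which the group on this saturated ring carbon changes, not only its configuration. In this assay, (methylamino)carbamoyl in place of aminomethyl gives a 16-fold lower number from compound 1 to compound 4 (1.20 log units; beyond the scatter), so the group at this carbon can move the number beyond the scatter. Nothing shown accounts for this step. From the compounds shown here alone, whether it comes from the carbonyl or from the methylamino end remains open, as does what a carboxylic acid, a simple amide or a longer chain would give at this carbon.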